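Swapping a Dichlorophenoxy for a Fluorophenoxy Group

This account rests on a few compounds, and the source may have more. Where it says the series, first, only, none or still open, it means among the compounds named here.

Measured compounds:
- Compound 1 `Nc1cc(N)c2nc(-c3ccccc3)c(Oc3ccc(Cl)c(Cl)c3)nc2c1`: 83200 nM
- Compound 2 `COc1ccc(CNc2nc3cc(N)cc(N)c3nc2-c2ccccc2)cc1OC`: 77600 nM

Of the compounds shown here, two that share one core have been tested in a functional assay on SK-MEL-5 cells (Homo sapiens) for inhibition, read by sulforhodamine B assay, with a stated time of 48 h; on this read-out lower numbers stand for higher toxicity in this test and higher numbers for lower toxicity in this test. Compound 1 gives 83200 nM, and compound 2 gives 77600 nM. Compound 1 has the highest number of the two, but the gap to compound 2 lies within the usual scatter of this assay, so the two results cannot be told apart; both point to weak toxicity toward these cells.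

Compound 3 `Nc1cc(N)c2nc(-c3ccccc3)c(Oc3ccc(F)cc3)nc2c1` is not yet measured. It differs from compound 1 in one spot: 4-fluorophenyl in place of 3,4-dichlorophenyl on an oxygen on an aromatic ring. Among the compounds with values here, no pair of measured compounds shows what such a swap does here, so the expectation rests on the weak toxicity seen for compound 1 with 83200 nM and the closeness of compound 2. For compound 3, the step of a 1.2-fold higher number from compound 1 to compound 3 (0.08 log units; within the scatter) is expected to be small, at most a modest shift toward a higher number, and it may well stay within the scatter. Compound 3 is therefore estimated to give 100000 nM in this assay, with a likely range from 40000 nM to 250000 nM.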

Compound 3, concentration lethal to 50% of the cells: 83200 nM
Compound 3: the middle estimate sits 1.2-fold (0.08 log units) above what was measured, and the stated range covers the measured number.
By their numbers in this assay, from the lowest: compounds 2, 1 and 3 (each within the scatter of the next).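

Within the data shown here, the swap of 3,4-dichlorophenyl for 4-fluorophenyl on an oxygen on an aromatic ring gives the first direct look at this position in this assay, and the result is no change at the digits printed from compound 1 to compound 3 (within the scatter). Within this pair, then, taking away the two chlorine atoms and adding one fluorine leaves the read-out indistinguishable, so this particular change gives no sign of altering toxicity toward these cells. No independent measurement is available to explain this outcome.

The compounds shown leave open whether this position can affect the read-out at all, since the only two groups compared there are both halogen-bearing phenyl rings attached through the same oxygen. A phenyl ring carrying an amine or a carboxylic acid, or a longer alkyl chain in place of the ring, would test whether a more different group on that oxygen moves the number or whether this part of the molecule has little influence in this test.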